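Cytotoxicity notes: the step to compound 4

A few compounds are considered here, and "the series" means these few. Any claim that something is new, unique, unknown or untested is made for them only; others in the source may bear on it.

Values in an ADME assay on HEK-293T cells (Homo sapiens) for cytotoxicity, read by luminescence, with a stated time of 24 h; on this read-out lower numbers stand for higher toxicity in this test and higher numbers for lower toxicity in this test:
- compound 1 `COc1ccc(Cn2c(C(=O)N3CCCCC3)cc3sccc32)cc1`: > 100000 nM (a limit of the assay)
- compound 2 `COc1ccc(Cn2c(C(=O)N3CCC(C(=O)NCc4ccccc4)CC3)cc3sccc32)cc1`: > 100000 nM (a limit of the assay)
- compound 3 `COc1ccc(Cn2c(C(=O)N3CCC(C(=O)NCC4CC4)CC3)cc3sccc32)cc1`: 24600 nM

For the measured compounds named here, compound 3, at 24600 nM, holds the only actual number in the set. The other two compounds rest on (the limit of > 100000 nM in this assay, at which 2 of the 3 values shown sit).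

The next compound is compound 4 `COc1ccc(Cn2c(C(=O)N3CCC(C(=O)NCCC(C)C)CC3)cc3sccc32)cc1`, which differs from compound 3 as follows: isobutyl in place of cyclopropyl on a saturated chain carbon bound to an amide-type nitrogen. In words, isobutyl stands in place of cyclopropyl on a saturated chain carbon bound to an amide-type nitrogen, so that (cyclopropylmethyl)carbamoyl becomes isopentylcarbamoyl.

The measured steps that bear on this place are an at least 4.0-fold lower number from compound 2 to compound 3 (0.60 log units; beyond the scatter) and an at least 4.0-fold lower number from compound 1 to compound 3 (0.60 log units; beyond the scatter). Both are minimum sizes, as each starts from a limit. The step that the two limits leave unreadable from compound 1 to compound 2 gives no size. Compound 4, like compound 3, carries no phenyl at this place, so a change beyond the scatter is not expected, although an at least 4.0-fold lower number from compound 2 to compound 3 (0.60 log units; beyond the scatter) shows that this place can move the number in this assay. The expected outcome is a 1.2-fold higher number from compound 3 to compound 4 (0.09 log units; within the scatter). The estimated value for compound 4 is 30000 nM, with an expected range from 11000 nM to 90000 nM.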

Compound 4, half-maximal cytotoxic concentration: 30900 nM
Estimate against measurement, compound 4: 1.0-fold (0.01 log units) below; low and high end bracket the measured number.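

In this assay, a 1.3-fold higher number from compound 3 to compound 4 (0.10 log units; within the scatter): at this place on a saturated chain carbon bound to an amide-type nitrogen, the open-chain isobutyl and the three-membered ring of cyclopropyl give values within the scatter of each other, so the ring is not needed for the number seen with compound 3. The drop linked to leaving phenyl now appears with a second group, as an at least 3.2-fold lower number from compound 2 to compound 4 (0.51 log units; beyond the scatter), while the comparison with the plain amide of the shared core gives an at least 3.2-fold lower number from compound 1 to compound 4 (0.51 log units; beyond the scatter), so two different carbamoyl chains without phenyl now stand apart from compound 2 and compound 1, though compound 1 carries no carbamoyl group at all. Both of these steps are minimum sizes, as each starts from a limit: the limit of > 100000 nM in this assay, at which 2 of the 4 values shown sit.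

On these data alone, whether the low-end numbers hold for a longer chain such as octyl, or for a chain ending in an amine or a carboxylic acid, stays open. Also open, as far as these compounds go, is whether phenyl itself sets compound 2 apart, or whether a pyridyl ring on the same chain carbon would read the same way.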